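Swapping a Para Substituent on an Arylsulfonamide

A few compounds are considered here, and "the series" means these few. Any claim that something is new, unique, unknown or untested is made for them only; others in the source may bear on it.

Measured compounds:
compound 1, `CCc1ccccc1NS(=O)(=O)c1ccc(N2CCNC2=O)cc1`, 240 nM
compound 2, `O=C1NCCN1c1ccc(S(=O)(=O)Nc2ccc(OC(F)F)cc2)cc1`, 650 nM
compound 3, `COc1ccccc1NS(=O)(=O)c1ccc(N2CCNC2=O)cc1`, 550 nM

The three measured compounds share one core and differ only in the group carried on the aniline ring. In a functional assay on HT-29 cells (Homo sapiens) for antiproliferative activity, read by sulforhodamine B assay, with a stated time of 48 h (on this read-out higher numbers stand for weaker inhibition and lower numbers for stronger inhibition), compound 2 gives the highest of the three numbers; its gap to compound 3 lies within the scatter, while its gap to compound 1 lies beyond it, so compound 2 is among the weaker inhibitors here.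

Compound 4, `Cc1ccc(NS(=O)(=O)c2ccc(N3CCNC3=O)cc2)cc1`, is not yet measured. It differs from compound 2 by methyl in place of difluoromethoxy on an aromatic carbon.

Among the compounds with values here, only one measured step bears on such an exchange of an alkoxy for an alkyl group: a 2.3-fold higher number from compound 1 to compound 3 (0.36 log units; beyond the scatter). That step runs in the direction alkyl to alkoxy and weakened inhibition modestly. Reading it in reverse suggests that replacing an alkoxy-type group with an alkyl group may give a somewhat lower number, but the groups and their place on the ring are not the same, so the carry-over is uncertain.

Compound 4 is therefore expected to come in at 350 nM, within a range of 150 nM to 800 nM, which amounts to an expected step of a 1.9-fold lower number from compound 2 to compound 4 (0.27 log units; within the scatter).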

Compound 4, half-maximal inhibitory concentration: 480 nM
Beside the measured number, compound 4's estimate is 1.4-fold (0.14 log units) below it; the range from low to high includes it.
By their numbers in this assay, from the lowest: compounds 1, 4, 3 and 2 (each within the scatter of the next, the first and the last beyond it).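

In this assay, putting methyl in place of difluoromethoxy on an aromatic carbon para to a large group gives a 1.4-fold lower number from compound 2 to compound 4 (0.13 log units; within the scatter) and so does not separate the two groups, even though methyl is the smaller by heavy atoms and has no hydrogen-bond acceptor. Compound 4 also stays close to the two compounds that carry their group elsewhere on the ring, with 4-methylphenyl in place of 2-methoxyphenyl on the sulfonamide nitrogen giving a 1.1-fold lower number from compound 3 to compound 4 (0.06 log units; within the scatter) and with 4-methylphenyl in place of 2-ethylphenyl giving a 2.0-fold higher number from compound 1 to compound 4 (0.30 log units; within the scatter) as a step that is also within the scatter, so compound 4 does not resolve which arrangement is better, although a 2.3-fold higher number from compound 1 to compound 3 (0.36 log units; beyond the scatter) does separate its two ends. No measurement shown here accounts for these small steps.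

From the compounds shown here alone, it remains open how an amine, a carboxylic acid or a longer chain on this aromatic carbon would read out. The compounds shown also never place one and the same group at two different spots on the aniline ring, so the effect of the group and the effect of its place cannot be told apart.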